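The source may report more compounds than this note shows. Statements on the series, on what has been measured and on what is new or still open speak of the compounds shown alone.

The three measured compounds share one core and differ in the arm on the saturated chain carbon bound to the amide-type nitrogen and in the aryl group on the urea. In a functional assay on B16-F10 cells (Mus musculus) for cytotoxicity, read by MTT assay, with a stated time of 48 h (a higher number here means a weaker inhibitor, a lower number a stronger inhibitor), compound 1 `COc1cc(CN(C(=O)Nc2ccc(C)cc2)n2cnnc2)cc(OC)c1OC` gives 46800 nM. Compound 3 `O=C(Nc1ccccc1)N(Cc1ccccn1)n1cnnc1` gives 23700 nM in this assay. For compound 2 `COc1ccc(CN(C(=O)Nc2ccc(Cl)c(C(F)(F)F)c2)n2cnnc2)cc1OC` the result in this assay is not a number but a limit, > 50000 nM. Compound 2 therefore stands at the limit of > 50000 nM in this assay, at which 1 of the 3 values shown sits, and nothing more than that can be said of where it sits among the three.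

Compound 4 `Cc1ccsc1CN(C(=O)Nc1ccc(Cl)c(C(F)(F)F)c1)n1cnnc1` is not yet measured. It differs from compound 2 in one place: 3-methylthiophen-2-yl in place of 3,4-dimethoxyphenyl on a saturated chain carbon bound to an amide-type nitrogen. Within the data shown here, no step between two measured compounds shows how such a change moves the read-out, so the expectation for compound 4 rests on compound 2 alone, whose value is a limit. The step of an at least 1.1-fold lower number from compound 2 to compound 4 (0.04 log units; that floor lies within the scatter) is expected to be small, if any, and within the scatter. For compound 4 the estimate in this assay is 45000 nM, with a range from 15000 nM to 100000 nM.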

Compound 4, half-maximal inhibitory concentration: 22100 nM
Beside the measured number, compound 4's estimate is 2.0-fold (0.31 log units) above it, and the stated range covers the measured number.
By their numbers in this assay, from the lowest: compounds 4, 3 and 1 (each within the scatter of the next, the first and the last beyond it). At a limit, above all of these: compound 2.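

In this assay, the arm on a saturated chain carbon bound to an amide-type nitrogen proves able to move the read-out while the rest of the molecule stays the same: 3-methylthiophen-2-yl in place of 3,4-dimethoxyphenyl gives an at least 2.2-fold lower number from compound 2 to compound 4 (0.35 log units; beyond the scatter). This is the first step shown between two measured compounds that differ in one place, and it lies beyond the scatter. Its size is only a floor because the result for compound 2 is a limit: the limit of > 50000 nM in this assay, at which 1 of the 4 values shown sits.

As far as these compounds go, it remains open whether the lower number follows from the thiophene ring itself or from its methyl group, which an unsubstituted thiophen-2-yl arm would help to separate. From the compounds shown here alone, it is also open how this position would respond to an arm carrying an amine or a carboxylic acid.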